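The source may report more compounds than this note shows. Statements on the series, on what has been measured and on what is new or still open speak of the compounds shown alone.

Of the compounds shown here, three sharing one core have been tested in an ADME assay on NIH3T3 cells (Mus musculus) for cytotoxicity, read by MTT assay, with a stated time of 24 h; a lower number here means a stronger inhibitor, a higher number a weaker inhibitor. Compound 1 `O=C(CSc1nnc(-c2ccncc2)o1)N/N=C/c1ccc(Cl)cc1` gives 181000 nM. Compound 2 `COc1ccc(/C=N/NC(=O)CSc2nnc(-c3ccncc3)o2)cc1` gives 132000 nM, and compound 3 `O=C(CSc1nnc(-c2ccncc2)o1)N/N=C/c1cccc(C(F)(F)F)c1` gives 169000 nM. Compound 2 shows the lowest of the three numbers, but its gaps to the other two lie within the scatter, so the three stand level in this assay. Within the data shown here, the one directly comparable change, a 1.4-fold lower number from compound 1 to compound 2 (0.14 log units; within the scatter), also lies within the scatter.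

Compound 4 `O=C(CSc1nnc(-c2ccncc2)o1)N/N=C/c1cc(Br)cc(Br)c1O` is not yet measured. It differs from compound 2 in one place: 3,5-dibromo-2-hydroxyphenyl in place of 4-methoxyphenyl on a carbon with a double bond to nitrogen. Among the measured compounds shown here, no measured step exchanges this kind of group, so the only guide is that the changes seen so far have left the numbers essentially unmoved. The expectation for compound 4 is therefore a number close to that of compound 2, with a somewhat lower value judged a little more likely than a higher one, an estimated step of a 1.5-fold lower number from compound 2 to compound 4 (0.17 log units; within the scatter). Compound 4 is estimated at 90000 nM, within a range from 35000 nM to 230000 nM.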

Compound 4, half-maximal inhibitory concentration: 190000 nM
The estimate for compound 4 lay 2.1-fold (0.32 log units) below the measured number; measured number inside the range.
By their numbers in this assay, from the lowest: compounds 2, 3, 1 and 4 (each within the scatter of the next).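

Exchanging 4-methoxyphenyl for 3,5-dibromo-2-hydroxyphenyl on the carbon with a double bond to nitrogen adds two bromine atoms and a hydrogen-bond donor, yet in this assay it gives a 1.4-fold higher number from compound 2 to compound 4 (0.16 log units; within the scatter) and leaves the number within the scatter. Exchanging 4-chlorophenyl for the same group gives a 1.0-fold higher number from compound 1 to compound 4 (0.02 log units; within the scatter), so this position has now taken a heavily changed aromatic ring without any readable shift, and all four compounds stand level. No supporting measurement bears on this result.

Going by these compounds, all four compounds keep a six-membered aromatic ring of carbon at this position, so it remains open whether a ring carrying an amine or a carboxylic acid, or a plain alkyl chain in place of the ring, would move the number beyond the scatter. On these data alone, the effect of any change to the shared core also remains open.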